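Amide aryl variation: from compound 2 to compound 3

This account rests on a few compounds, and the source may have more. Where it says the series, first, only, none or still open, it means among the compounds named here.

Compound 1 `O=C(COc1ccc2cc(/C=C3/SC(=O)NC3=O)ccc2c1)Nc1ccccc1` and compound 2 `O=C(COc1ccc2cc(/C=C3/SC(=O)NC3=O)ccc2c1)Nc1ccc([N+](=O)[O-])cc1` share one core and differ only in the aryl group on the amide nitrogen. In an assay on isolated protein for inhibition of histone deacetylase 8 (Homo sapiens), with a stated time of 1 h (on this read-out lower numbers stand for stronger inhibition and higher numbers for weaker inhibition), compound 1 gives 4500 nM. In this assay compound 2 gives 4000 nM. The step of a 1.1-fold lower number from compound 1 to compound 2 (0.05 log units; within the scatter) lies within the scatter, so compound 2 holds the lower of the two numbers without standing apart from compound 1.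

Compound 3 `O=C(COc1ccc2cc(/C=C3/SC(=O)NC3=O)ccc2c1)Nc1ccc(Cl)c(Cl)c1` carries the change (3,4-dichlorophenyl in place of 4-nitrophenyl on an amide-type nitrogen). For the measured compounds named here, only one measured step bears on this position: a 1.1-fold lower number from compound 1 to compound 2 (0.05 log units; within the scatter), a swap of hydrogen for nitro that left the read-out essentially unchanged. Going by the values given here, no measured step removes a nitro group or introduces chlorine on this aryl ring, so the direction of any effect of the dichloro pattern is not known from these data. Given that the one available step was flat, the expected step of a 1.1-fold lower number from compound 2 to compound 3 (0.06 log units; within the scatter) is small and within the scatter, with no direction claimed. Compound 3 is estimated at 3500 nM, with a range from 1200 nM to 10000 nM.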

Compound 3, half-maximal inhibitory concentration: > 50000 nM
Compound 3: no number, only a limit; the forecaster's own chance of this, stated with the estimate: 5%; middle value at least 14-fold (1.15 log units) away from the limit.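

For the compounds shown here, on the amide-type nitrogen, the aryl group is not a free position in this assay: 3,4-dichlorophenyl in place of 4-nitrophenyl gives an at least 12-fold higher number from compound 2 to compound 3 (1.09 log units; beyond the scatter), and 3,4-dichlorophenyl in place of phenyl gives an at least 11-fold higher number from compound 1 to compound 3 (1.04 log units; beyond the scatter), both large and beyond the scatter, whereas the only earlier change at this position, a 1.1-fold lower number from compound 1 to compound 2 (0.05 log units; within the scatter), stayed within it. Compound 3 carries a limit of the assay and not a number: the limit of > 50000 nM in this assay, at which 1 of the 3 values shown sits. Both new steps therefore fix only a smallest size, and the position now separates one aryl pattern, 3,4-dichlorophenyl, from two others, phenyl and 4-nitrophenyl, that lie within the scatter of each other.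

The two chlorines enter together, so the compounds shown do not separate the pair from a phenyl ring carrying a single chlorine. They also leave open whether a methoxy group, an amine or a carboxylic acid on this aryl ring keeps the read-out with compound 1 and compound 2 or moves it towards compound 3.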